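A few compounds are considered here, and "the series" means these few. Any claim that something is new, unique, unknown or untested is made for them only; others in the source may bear on it.

In a functional assay on MCF7 cells (Homo sapiens) for cytotoxicity, read by MTT assay, with a stated time of 72 h (a lower number here means a stronger inhibitor, a higher number a weaker inhibitor), compound 1 (`O=C(N/N=C/c1cc(Br)c(O)c(Br)c1)Nc1cc2c(Nc3ccc(F)c(Cl)c3)ncnc2cc1O[C@H]1CCOC1`) gives 5910 nM and compound 2 (`COc1cc2ncnc(Nc3ccc(F)c(Cl)c3)c2cc1NC(=O)N/N=C/c1cccc(Cl)c1Cl`) gives 28700 nM, so compound 2 holds the higher, weaker number of the two, a gap beyond the scatter. Compound 3 (`COc1cc2ncnc(Nc3ccc(F)c(Cl)c3)c2cc1NC(=O)N/N=C/c1cc(Br)c(O)c(Br)c1`) keeps the core of compound 2 and changes one group: 3,5-dibromo-4-hydroxyphenyl in place of 2,3-dichlorophenyl on a carbon with a double bond to nitrogen. Compound 1 carries that entering group on a different core and gives 5910 nM, which points to a lower number. The expected change in this assay is an estimated 3.2-fold lower number from compound 2 to compound 3 (0.50 log units; beyond the scatter), moderate in size. The estimate for compound 3 is 9000 nM, within a range of 3500 nM to 23000 nM.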

Compound 3, half-maximal inhibitory concentration: 30200 nM
Compound 3: the middle estimate sits 3.4-fold (0.53 log units) below what was measured; measured number outside the range, above it.
By their numbers in this assay, from the lowest: compound 1; then compounds 2 and 3 (each within the scatter of the next).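

In this assay, 3,5-dibromo-4-hydroxyphenyl in place of 2,3-dichlorophenyl on a carbon with a double bond to nitrogen makes no readable difference on this core (a 1.1-fold higher number from compound 2 to compound 3 (0.02 log units; within the scatter)). The lower number of compound 1 therefore goes with the other place of difference, methyl in place of oxolan-3-yl on an oxygen on an aromatic ring (a 5.1-fold higher number from compound 1 to compound 3 (0.71 log units; beyond the scatter)). No measurement shown explains either result. Still open, from the compounds shown here alone, is how a longer chain ending in an amine would read on that oxygen, and how a plain phenyl would read on that carbon.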